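The compounds below may be only part of what the source reports. "The series", "measured", "known", "first", "only" and "open" are said of these compounds alone.

The shared core is carried by compound 1 `O=C(Nc1cccc(-c2oc3cc(-c4ccc(F)cc4)ccc3c(=O)c2O)c1)c1ccccc1F` and compound 2 `O=C(Nc1cccc(-c2oc3cc(-c4ccc(F)cc4)ccc3c(=O)c2O)c1)c1ccc(C(F)(F)F)cc1`, which differ only in the aryl group on the carbonyl carbon of the amide. In a functional assay on HCC1937 cells (Homo sapiens) for antiproliferative activity, read by CCK-8 assay, with a stated time of 72 h (on this read-out lower numbers stand for stronger inhibition and higher numbers for weaker inhibition), compound 1 gives 10800 nM, and in the same assay compound 2 gives 7350 nM. Going by the values given here, the only step measured so far, a 1.5-fold lower number from compound 1 to compound 2 (0.17 log units; within the scatter), therefore places compound 2 alongside compound 1 rather than apart from it, and the two numbers do not separate. Compound 3 `O=C(Nc1cccc(-c2oc3cc(-c4ccc(F)cc4)ccc3c(=O)c2O)c1)c1ccc(Br)cc1` is the next member, reached from compound 2 by bromo in place of trifluoromethyl on an aromatic carbon. Among the compounds with values here, no measured step covers an exchange of this kind; the one step available, between compound 1 and compound 2, changed the same aryl group and stayed within the scatter, so nothing points toward a move beyond the scatter in this assay. Compound 3 is therefore expected to come in at about 7000 nM, with a likely range of 2500 nM to 20000 nM, which means an expected step of a 1.1-fold lower number from compound 2 to compound 3 (0.02 log units; within the scatter).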

Compound 3, half-maximal inhibitory concentration: 8630 nM
Compound 3: middle estimate off by 1.2-fold (0.09 log units), on the low side; the range from low to high includes it.
By their numbers in this assay, from the lowest: compounds 2, 3 and 1 (each within the scatter of the next).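

The exchange of trifluoromethyl for bromo, on an aromatic carbon para to a large group, is the first change shown that replaces one substituent on the 4-position of this aryl ring with another, and in this assay it stays within the scatter (a 1.2-fold higher number from compound 2 to compound 3 (0.07 log units; within the scatter)). Set against the 2-fluorophenyl group, the 4-bromophenyl group also stays within the scatter (a 1.3-fold lower number from compound 1 to compound 3 (0.10 log units; within the scatter)), so none of the three aryl groups on the carbonyl carbon separates from the others. Nothing measured here offers an explanation for these steps.

The compounds shown leave open whether an amine or a carboxylic acid in place of bromo would move the number beyond the scatter. They also leave open whether a longer alkyl chain in place of the whole aryl group would do so.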